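Swapping the aryl group on a piperazine amide

A few compounds are considered here, and "the series" means these few. Any claim that something is new, unique, unknown or untested is made for them only; others in the source may bear on it.

Measured compounds:
compound 1 `O=C(CN1CCN(c2ncccn2)CC1)Nc1nc2ccccc2[nH]1`, 15%
compound 2 `O=C(CN1CCN(c2ccc([N+](=O)[O-])cc2)CC1)Nc1nc2ccccc2[nH]1`, 57.3%

Within the data shown here, in an assay on isolated protein for inhibition of Rho-associated protein kinase 2 (Homo sapiens), read by immunoassay, with a stated time of 30 min, tested at 0.5 mM (a lower number here means less inhibition, a higher number more inhibition at the concentration tested (going by the name of the read-out)), compound 2 stands highest of the two numbers; the only other compound, compound 1, sits well below it, as the step of a number 42.3 percentage points higher from compound 1 to compound 2 (beyond the scatter) shows. Compound 3 `COc1ccccc1N1CCN(CC(=O)Nc2nc3ccccc3[nH]2)CC1` differs from compound 2 by 2-methoxyphenyl in place of 4-nitrophenyl on an amine nitrogen in a ring. Among the measured compounds shown here, the one step known here, from a pyrimidinyl to a nitrophenyl group on that ring nitrogen, was large, so the identity of this group matters. Without a measured methoxyphenyl analogue, compound 3 is expected to fall between the two, a step of a number 22.3 percentage points lower from compound 2 to compound 3 (beyond the scatter), giving an estimated 35% (range 10% to 60%).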

Compound 3, a percentage reported as inhibition, at one concentration (the size of the read-out at that concentration, not a potency) in the Rho-associated protein kinase 2 assay: 25.3%
Compound 3: middle estimate off by 9.7 percentage points, on the high side; the measured number falls inside the stated range.
By their numbers in the Rho-associated protein kinase 2 assay, from the lowest: compound 1; then compound 3; then compound 2.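

In the Rho-associated protein kinase 2 assay, the new group gives a second large change at this ring nitrogen, a number 32 percentage points lower from compound 2 to compound 3 (beyond the scatter), while a number 10.3 percentage points higher from compound 1 to compound 3 (beyond the scatter). Compound 2 and compound 3 both carry a six-membered aromatic ring of carbon only, so that ring alone does not bring the higher number; what hangs on it matters. In a physicochemical assay for lipophilicity, read by spectrophotometry, using the shake flask method, measured as octanol-water partition, with a stated time of 24 h (on this read-out lower numbers stand for lower lipophilicity and higher numbers for higher lipophilicity), compound 2 gives 1.94 and compound 3 gives 0.97. Lipophilicity falls along the same step, a possible contributor, in the physicochemical assay: the measured partition coefficient of compound 2, 1.94, and of compound 3, 0.97, a number 0.97 log units lower (beyond the scatter)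

On these data alone, whether the nitro group, the methoxy group or their places on the ring drive the gap stays open. A plain phenyl group or 4-methoxyphenyl on the same nitrogen would help separate these.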